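The source may report more compounds than this note shows. Statements on the series, on what has been measured and on what is new or still open speak of the compounds shown alone.

Measured so far:
compound 1 `CCCCCc1c(C(C)C)nc(C(C)C)c(CO)c1-c1cccc2ccccc12`: 6%
compound 2 `CCCCCc1c(C(C)C)nc(C(C)C)c(CO)c1-c1cccc(Cl)c1`: 49%
compound 3 `CCC/C=C/c1c(C(C)C)nc(C(C)C)c(CO)c1-c1ccc(Cl)c(Cl)c1`: 39%

Of the compounds shown here, three built on a shared core have been tested in an assay on CHO cells for inhibition of Glucagon receptor (Homo sapiens), tested at 20 uM; on this read-out higher numbers stand for more inhibition at the one concentration tested (going by the name of the read-out) and lower numbers for less inhibition. Compound 2 gives the highest of the three numbers. Compound 3 lies close to it, within the usual scatter of repeated measurements of this kind, so the two cannot be told apart on these data. Compound 1 sits well below compound 2, beyond the scatter. Within the data shown here, no pair among the three differs in only one place, so none of these gaps can be tied to a single change in structure.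

Compound 4 `CCCCCc1c(C(C)C)nc(C(C)C)c(CO)c1-c1ccccc1OC` has not yet been measured. It differs from compound 2 in one place: 2-methoxyphenyl in place of 3-chlorophenyl on an aromatic carbon. Among the measured compounds shown here, no measured pair shows what an exchange of this kind does on this core, so the expectation rests on the three numbers alone. Going by them, the step of a number 17 percentage points lower from compound 2 to compound 4 (beyond the scatter) is expected to be a modest decrease, possibly no larger than the scatter. Compound 4 is estimated to give 32% in this assay, within a range from 5% to 60%.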

Compound 4, a percentage reported as inhibition, at one concentration (the size of the read-out at that concentration, not a potency): 27%
The estimate for compound 4 lay 5 percentage points above the measured number, within the range that was stated.
By their numbers in this assay, from the lowest: compound 1; then compound 4; then compounds 3 and 2 (each within the scatter of the next).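

In this assay, among these compounds, exchanging 3-chlorophenyl for 2-methoxyphenyl on the shared core gives a number 22 percentage points lower from compound 2 to compound 4 (beyond the scatter), the first step that can be tied to a change in one place, and it shows that the group on this aromatic carbon affects inhibition. The exchange alters both the substituent on the phenyl ring and where that substituent sits, so this one step cannot separate the two changes. Nothing measured here accounts for the size of the step.

The compounds shown leave open how 3-methoxyphenyl, 2-chlorophenyl or unsubstituted phenyl would compare at this position, and these are the groups that could pull the two changes apart. They also leave open what a phenyl ring carrying an amine or a carboxylic acid would do here.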